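Swapping a prenyl ether for a fluorophenyl carbamate

A few compounds are considered here, and "the series" means these few. Any claim that something is new, unique, unknown or untested is made for them only; others in the source may bear on it.

Measured so far:
Compound 1 `CC(C)=CCC/C(C)=C/CC1Cc2c(OCC=C(C)C)cc(=O)n(CCCO)c2CC1(C)C`: 30.3%
Compound 2 `CC(C)=CCC/C(C)=C/CC1Cc2c(OCCCOc3ccc([N+](=O)[O-])cc3)cc(=O)n(CCCO)c2CC1(C)C`: 65.1%

In a functional assay on PANC-1 cells (Homo sapiens) for inhibition, read by MTT assay, with a stated time of 24 h, tested at 10 uM (a lower number here means less inhibition, a higher number more inhibition at the concentration tested (going by the name of the read-out)), compound 1 gives 30.3%, the lowest of the two numbers measured; compound 2 stands a number 34.8 percentage points higher from compound 1 to compound 2 (beyond the scatter). Compound 3 `CC(C)=CCC/C(C)=C/CC1Cc2c(OC(=O)Nc3cccc(F)c3)cc(=O)n(CCCO)c2CC1(C)C` is not yet measured. Its difference from compound 1 is (3-fluorophenyl)carbamoyl in place of 3-methylbut-2-en-1-yl on an oxygen on an aromatic ring. For the measured compounds named here, the only measured step that bears on this change is the one from compound 1 to compound 2, where the 3-methylbut-2-en-1-yl group was also exchanged for a larger group carrying a six-membered aromatic ring, and the read-out rose a number 34.8 percentage points higher from compound 1 to compound 2 (beyond the scatter). Since compound 3 likewise gains an aromatic ring in that position, an increase in this assay is expected, though the entering group is different, so the size is uncertain. The step for compound 3 is estimated at a number 19.7 percentage points higher from compound 1 to compound 3 (beyond the scatter). Compound 3 is therefore expected to give about 50%, within 28% to 72%.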

Compound 3, a percentage reported as inhibition, at one concentration (the size of the read-out at that concentration, not a potency): 52.3%
Estimate against measurement, compound 3: 2.3 percentage points below, and the stated range covers the measured number.
By their numbers in this assay, from the lowest: compound 1; then compound 3; then compound 2.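

In this assay, the read-out stands a number 22 percentage points higher from compound 1 to compound 3 (beyond the scatter) when (3-fluorophenyl)carbamoyl replaces 3-methylbut-2-en-1-yl on the oxygen on the aromatic ring. This shows that the rise seen earlier at this position is not limited to one entering group, since a second group carrying a six-membered aromatic ring, joined through a carbamoyl unit with a hydrogen-bond donor rather than a saturated chain, also gives a rise beyond the scatter. No separate measurement is at hand to explain this rise.

The compounds shown leave open whether the fluorine matters, which an unsubstituted phenylcarbamoyl group would test. They also leave open whether the aromatic ring matters, which a cyclohexylcarbamoyl group, with a saturated ring in its place, would test.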